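The source may hold more compounds than are shown below. What is called first, only, known or untested is meant among the compounds shown, and "the series" means these compounds.

Two compounds share one core and differ only in the group carried on the ring nitrogen. In an in vitro assay on 293-EBNA cells for binding affinity to corticotropin-releasing factor receptor 1 (Homo sapiens) (a lower number here means a stronger inhibitor, a higher number a weaker inhibitor), compound 1 `CCC(COC)Nc1nc(C)nc2c1nnn2-c1c(C)cc(C)cc1C` gives 59.4 nM. In this assay compound 2 `CCCCC(CC)Nc1nc(C)nc2c1nnn2-c1c(C)cc(C)cc1C` gives 7.6 nM. Between them lies a single change: a 7.8-fold lower number from compound 1 to compound 2 (0.89 log units; beyond the scatter). Among the compounds with values here, compound 2 thus holds the lowest number of the two, and its only neighbour is compound 1, which stands clearly higher.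

Compound 3 `CCCC(C)Nc1nc(C)nc2c1nnn2-c1c(C)cc(C)cc1C` is not yet measured. It differs from compound 2 by 1-methylbutyl in place of 1-ethylpentyl on a nitrogen on an aromatic ring, a shorter branched chain on the same nitrogen. Within the data shown here, only one measured step touches this position, a 7.8-fold lower number from compound 1 to compound 2 (0.89 log units; beyond the scatter), and that step swapped a methoxy for a carbon chain rather than shortening a chain, so it bears on the new step only loosely. Removing chain carbons from compound 2 is expected to cost some affinity, giving a 2.6-fold higher number from compound 2 to compound 3 (0.42 log units; beyond the scatter). Compound 3 is therefore estimated at 20 nM, between 7 nM and 60 nM.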

Compound 3, inhibition constant: 7.1 nM
Compound 3: middle estimate off by 2.8-fold (0.45 log units), on the high side; the measured number falls inside the stated range.
By their numbers in this assay, from the lowest: compounds 3 and 2 (each within the scatter of the next); then compound 1.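

In this assay, 1-methylbutyl in place of 1-ethylpentyl on the nitrogen gives a 1.1-fold lower number from compound 2 to compound 3 (0.03 log units; within the scatter), so at this position the two branched carbon chains cannot be told apart. The shorter chain therefore gives up nothing that this read-out can detect, and the extra carbons of 1-ethylpentyl are not needed to reach this level of binding. The comparison with the methoxy-bearing group gives an 8.4-fold lower number from compound 1 to compound 3 (0.92 log units; beyond the scatter), so a second all-carbon chain now shows the same gap from compound 1 that compound 2 showed, and neither of the two goes against it.

Nothing in the data shown explains these numbers. As far as these compounds go, it remains open how far the chain can shrink or grow at this nitrogen, and whether a cyclopentyl group, a much longer chain or a chain ending in an amine would fit the same pattern.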